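Swapping a chlorobenzyl for a morpholine amide chain

This account rests on a few compounds, and the source may have more. Where it says the series, first, only, none or still open, it means among the compounds named here.

Of the compounds shown here, three have been measured for cytotoxicity, each bearing the same core and differing only in the group on a saturated chain carbon bound to an aromatic nitrogen.

Compound 1 `Cc1cccc(Cn2cc(CNC(=O)c3cnc(Nc4ccc(C#N)cc4)cc3Oc3c(C)cc(C)cc3C)nn2)c1` gives 114000 nM in an ADME assay on MT4 cells (Homo sapiens) for cytotoxicity, read by MTT assay, with a stated time of 5 days; a lower number here means that less compound is tolerated, a higher number that more compound is tolerated.
Compound 2 `Cc1cc(C)c(Oc2cc(Nc3ccc(C#N)cc3)ncc2C(=O)NCc2cn(Cc3ccccc3Cl)nn2)c(C)c1` gives >= 188000 nM in this assay, and that figure is a limit of the assay rather than a number.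
Compound 3 `Cc1cc(C)c(Oc2cc(Nc3ccc(C#N)cc3)ncc2C(=O)NCc2cn(CCC#N)nn2)c(C)c1` gives 40200 nM in this assay.

Compound 2 therefore stands only at the edge of what the assay reports: it sits at the limit of >= 188000 nM in this assay, at which 1 of the 3 values shown sits, and no finite value is known for it. Compound 4 `Cc1cc(C)c(Oc2cc(Nc3ccc(C#N)cc3)ncc2C(=O)NCc2cn(CC(=O)N3CCOCC3)nn2)c(C)c1` differs from compound 2 by one change: (morpholin-4-yl)carbonyl in place of 2-chlorophenyl on a saturated chain carbon bound to an aromatic nitrogen.

Within the data shown here, two measured steps bear on this change, since both trade a benzyl-type group for a small chain on the same carbon: an at least 4.6-fold lower number from compound 2 to compound 3 (0.66 log units; beyond the scatter) and a 2.8-fold lower number from compound 1 to compound 3 (0.45 log units; beyond the scatter). By contrast, an at least 1.6-fold higher number from compound 1 to compound 2 (0.21 log units; that floor lies within the scatter). Compound 4 is accordingly expected to show a lower number than the limit for compound 2, a modest step of an at least 2.6-fold lower number from compound 2 to compound 4 (0.42 log units; beyond the scatter). The estimated value for compound 4 in this assay is 70000 nM, with a range from 30000 nM to 188000 nM.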

Compound 4, half-maximal cytotoxic concentration: 181000 nM
For compound 4 the middle estimate is 2.6-fold (0.41 log units) below the measured one; the measured number falls inside the stated range.
By their numbers in this assay, from the lowest: compound 3; then compounds 1 and 4 (each within the scatter of the next). At a limit, above all of these: compound 2.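

In this assay, (morpholin-4-yl)carbonyl on the saturated chain carbon bound to an aromatic nitrogen gives a 4.5-fold higher number from compound 3 to compound 4 (0.65 log units; beyond the scatter) when it takes the place of cyanomethyl, so the earlier fall seen with cyanomethyl does not extend to every group without an aromatic ring at this position. Against 3-methylphenyl, the same group gives a 1.6-fold higher number from compound 1 to compound 4 (0.20 log units; within the scatter), and no difference between the two groups can be read from this step.

On these data alone, whether a carboxylic acid, an open-chain amine amide or a longer chain on this carbon would stay with compound 4 or fall towards compound 3 remains open. Against 2-chlorophenyl, (morpholin-4-yl)carbonyl gives an at least 1.0-fold lower number from compound 2 to compound 4 (0.01 log units; that floor lies within the scatter). How far the 2-chlorophenyl group lifts the number is unknown, since compound 2 is known only as a limit of the assay: the limit of >= 188000 nM in this assay, at which 1 of the 4 values shown sits.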